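Methoxy to chloro on the terminal ring of compound 2

A few compounds are considered here, and "the series" means these few. Any claim that something is new, unique, unknown or untested is made for them only; others in the source may bear on it.

Among the compounds with values here, compound 2 `COc1ccc(-c2ccc(-c3ccc(C(=N)N)o3)o2)cc1` gives 490 nM in a functional assay on K562 cells (Homo sapiens) for inhibition, read by sulforhodamine B assay, with a stated time of 48 h (on this read-out higher numbers stand for weaker inhibition of growth and lower numbers for stronger inhibition of growth), and stands lowest of the two numbers measured so far. Compound 1 `N=C(N)c1ccc(-c2ccc(-c3cc(Cl)cc(Cl)c3)s2)s1` gives 1290 nM in this assay, a higher number beyond the scatter; the two share no single-point change, so only the two values can be compared. Compound 3 `N=C(N)c1ccc(-c2ccc(-c3ccc(Cl)cc3)o2)o1` differs from compound 2 by chloro in place of methoxy on an aromatic carbon. Within the data shown here, no measured pair shows this change, so the step of a 1.3-fold higher number from compound 2 to compound 3 (0.12 log units; within the scatter) is expected to fall near or just beyond the scatter, toward a weaker number. Compound 3 is expected to give 650 nM, within 250 nM to 1700 nM.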

Compound 3, concentration for 50% growth inhibition: 1370 nM
Beside the measured number, compound 3's estimate is 2.1-fold (0.32 log units) below it; measured number inside the range.
By their numbers in this assay, from the lowest: compound 2; then compounds 1 and 3 (each within the scatter of the next).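

This gives the series its first single-point step: at the aromatic carbon para to a large group, chloro in place of methoxy gives a 2.8-fold higher number from compound 2 to compound 3 (0.45 log units; beyond the scatter) in this assay and the step lies beyond the scatter. The position therefore responds to the group it carries, with methoxy giving the lower number of this one pair. From the compounds shown here alone, whether an amine or a hydroxyl on the same carbon would give a lower number remains open, as does whether the same change would behave alike on the core of compound 1. No measurement available here accounts for the step.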